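This account rests on a few compounds, and the source may have more. Where it says the series, first, only, none or still open, it means among the compounds named here.

Of the compounds shown here, three built on one shared core have been tested in a functional assay on DU-145 cells (Homo sapiens) for cytotoxicity, read by MTT assay, with a stated time of 96 h; a lower number here means that less compound is needed, a higher number that more compound is needed for the effect. Compound 1 `CCOC(=O)/C(=C/c1c(-c2ccccc2)[nH]c2ccccc12)C(=O)c1ccccc1` gives 68000 nM in this assay. Compound 2 `CCOC(=O)/C(=C/c1c(-c2ccccc2)[nH]c2ccccc12)C(=O)c1ccc([N+](=O)[O-])cc1` carries a nitro group where compound 1 has a hydrogen; in this assay compound 2 gives 11000 nM, and this is a 6.2-fold lower number from compound 1 to compound 2 (0.79 log units; beyond the scatter). Compound 3 `COc1ccc(-c2[nH]c3ccc(OC)cc3c2/C=C(\C#N)S(=O)(=O)c2ccccc2)cc1` gives 3000 nM, the lowest of the three numbers: compound 2 stands nearest to it, and compound 1 stands furthest away.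

Compound 4 `COc1ccc(-c2[nH]c3ccccc3c2/C=C(\C#N)S(=O)(=O)c2ccccc2)cc1` is the next compound to be tested. It differs from compound 3 in one place: hydrogen in place of methoxy on an aromatic carbon. Going by the values given here, the only measured step, a 6.2-fold lower number from compound 1 to compound 2 (0.79 log units; beyond the scatter), concerns a nitro group entering elsewhere on the molecule and therefore bears only loosely on removing a methoxy; no measured pair here compares a methoxy with a hydrogen directly. Among the compounds with values here, with no directly comparable step, the expectation is that compound 4 stays near compound 3, and the estimated step of a 1.3-fold higher number from compound 3 to compound 4 (0.12 log units; within the scatter) is not expected to exceed the usual scatter. On that basis, compound 4 is expected to give about 4000 nM in this assay, with a range from 1500 nM to 12000 nM.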

Compound 4, half-maximal effective concentration: 2000 nM
Beside the measured number, compound 4's estimate is 2.0-fold (0.30 log units) above it, within the range that was stated.
By their numbers in this assay, from the lowest: compounds 4 and 3 (each within the scatter of the next); then compound 2; then compound 1.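

In this assay, putting hydrogen in place of methoxy on this aromatic carbon gives a 1.5-fold lower number from compound 3 to compound 4 (0.18 log units; within the scatter) and so leaves the two compounds indistinguishable in this measurement. This is the first pair shown that tests this position, and it indicates that the methoxy on this six-membered aromatic ring is not needed to keep the number at this level; the earlier step concerned a nitro group elsewhere, on a different compound pair, and could not show this. Nothing available explains why exchanging these two groups makes so little difference here.

The compounds shown cover only methoxy and hydrogen at this position, so it remains open whether an amine, a carboxylic acid or a longer chain such as butoxy would also leave the number unchanged or would shift it beyond the scatter. Compounds 3 and 4 also share a second methoxy on their other aromatic ring, and what replacing that group with hydrogen would do remains an open question.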